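Phenyl in Place of Pyridin-4-yl: Compound 3 to Compound 4

This account rests on a few compounds, and the source may have more. Where it says the series, first, only, none or still open, it means among the compounds named here.

Of the compounds shown here, three built on one shared core have been tested in a functional assay on HeLa cells (Homo sapiens) for antiproliferative activity, read by CCK-8 assay, with a stated time of 72 h, tested at 2 uM; on this read-out higher numbers stand for a stronger effect at the one concentration tested and lower numbers for a weaker effect. In this assay compound 1 `Nc1ccccc1NC(=O)c1ccc(CSC(=S)N2CCc3cc([N+](=O)[O-])ccc32)cc1` gives 32.6%, and compound 2 `CC1CCN(C(=S)SCc2ccc(C(=O)Nc3ccccc3N)cc2)CC1` gives 46.8%. Compound 3 `Nc1ccccc1NC(=O)c1ccc(CSC(=S)N2CCN(Cc3ccncc3)CC2)cc1` gives 59.5% in this assay, the highest of the three numbers: compound 2 is its nearest neighbour, lower by a margin beyond the scatter, and compound 1 is the furthest, lower by a margin also beyond the scatter.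

Compound 4 `Nc1ccccc1NC(=O)c1ccc(CSC(=S)N2CCN(Cc3ccccc3)CC2)cc1` has not yet been measured in this assay. It differs from compound 3 in one place: phenyl in place of pyridin-4-yl on a saturated chain carbon bound to an amine nitrogen in a ring. Within the data shown here, no pair of measured compounds that differ in a single place is available, so the size of such a change cannot be read from earlier data. The author therefore expects a step of modest size, a number 5.5 percentage points lower from compound 3 to compound 4 (within the scatter), one that may well stay within the usual scatter. On that basis compound 4 is estimated to give 54% in this assay, with a plausible range from 40% to 68%.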

Compound 4, a percentage reported as inhibition, at one concentration (the size of the read-out at that concentration, not a potency): 20.6%
Compound 4: middle estimate off by 33.4 percentage points, on the high side; measured number below the stated range.
By their numbers in this assay, from the lowest: compound 4; then compound 1; then compound 2; then compound 3.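

In this assay, phenyl in place of pyridin-4-yl on a saturated chain carbon bound to an amine nitrogen in a ring gives a number 38.9 percentage points lower from compound 3 to compound 4 (beyond the scatter), the first single-place step available in this series. The two groups have the same count of heavy atoms and are each one six-membered aromatic ring, differing in that pyridin-4-yl carries a ring nitrogen and a hydrogen-bond acceptor, and this exchange alone is enough for a large step at this position. Nothing at hand accounts for the size of that step.

Whether the place of the ring nitrogen matters remains open, since pyridin-3-yl and pyridin-2-yl are not among the compounds shown. Also open, as far as these compounds go, is how a longer chain between the aromatic ring and the amine nitrogen would read out.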